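Carbamoylmethyl in place of methyl on compound 3

The source may hold more compounds than are shown below. What is called first, only, known or untested is meant among the compounds shown, and "the series" means these compounds.

Of the compounds shown here, three have been measured so far. In a functional assay on HCT-116 cells (Homo sapiens) for antiproliferative activity, read by MTT assay, with a stated time of 48 h (a lower number here means a stronger inhibitor, a higher number a weaker inhibitor), compound 2 `COc1ccc(-c2cc3c(cn2)ncn3-c2cc(OC)c(OC)c(OC)c2)cc1O` gives 280 nM. Compound 3 `COc1ccc(-c2cc3c(cn2)n(C)c(=O)n3-c2cc(OC)c(OC)c(OC)c2)cc1O` gives 1060 nM, the higher of the two numerical values in the series, and its gap to compound 2 lies beyond the usual scatter. Compound 1 `COc1ccc(-n2c(=O)[nH]c3cnc(-c4cc(OC)c(OC)c(OC)c4)cc32)cc1O` reads > 20000 nM, which is a limit of the assay and not a number (the limit of > 20000 nM in this assay, at which 1 of the 3 values shown sits).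

The next compound to be measured is compound 4 `COc1ccc(-c2cc3c(cn2)n(CC(N)=O)c(=O)n3-c2cc(OC)c(OC)c(OC)c2)cc1O`. It carries carbamoyl in place of hydrogen on a saturated chain carbon bound to an aromatic nitrogen. Cut one bond further out, the same difference reads methyl to carbamoylmethyl.

Going by the values given here, no measured step covers this change, so the expectation rests only on the spread of the numerical values, with compound 3 at 1060 nM as the starting point. In this assay, a modest step toward a weaker inhibitor is expected, of a size not far beyond the scatter. The expected step is a 1.7-fold higher number from compound 3 to compound 4 (0.23 log units; within the scatter). For compound 4 the estimated value is 1800 nM, with an expected range from 500 nM to 7000 nM.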

Compound 4, half-maximal inhibitory concentration: 8890 nM
For compound 4 the middle estimate is 4.9-fold (0.69 log units) below the measured one; the measured number lies above the stated range.
By their numbers in this assay, from the lowest: compound 2; then compound 3; then compound 4. At a limit, above all of these: compound 1.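

In this assay, the saturated chain carbon bound to an aromatic nitrogen proves to be a position where the substituent matters, as carbamoyl in place of hydrogen there gives an 8.4-fold higher number from compound 3 to compound 4 (0.92 log units; beyond the scatter). Going by these compounds alone, this is the first step that can be read at this position, and it shows that extending the methyl of compound 3 to carbamoylmethyl costs activity, although compound 4 still gives a numerical value of 8890 nM and not a limit. No measured property among the data shown bears on this loss.

The compounds shown leave open whether the loss follows the carbamoyl group itself or simply the longer substituent, a question that an ethyl or propyl chain at the same place would help to separate. Also open, as far as these compounds go, is how a carboxylic acid, a methyl ester, a dimethylamide or a primary amine on the same chain would compare with compound 3 and compound 4, and whether any group at this position can match or improve on the methyl.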